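Adding bromo to the least cytotoxic thiourea of three

The source may report more compounds than this note shows. Statements on the series, on what has been measured and on what is new or still open speak of the compounds shown alone.

Compound 1 `CC[C@H]1CC[C@H](c2ccc(NC(=S)Nc3cccc(C(F)(F)F)c3)cc2)CC1`: 9000 nM
Compound 2 `CCCC[C@H]1CC[C@H](c2ccc(NC(=S)Nc3cccc(C(F)(F)F)c3)cc2)CC1`: 10000 nM
Compound 3 `FC(F)(F)c1cccc(NC(=S)Nc2ccccc2)c1`: 49000 nM

In an ADME assay on MDBK cells (Bos taurus) for cytotoxicity, read by MTT assay, with a stated time of 96 h (a lower number here means that less compound is tolerated, a higher number that more compound is tolerated), compound 3 stands highest of the three, at 49000 nM. Its two neighbours lie well under it, as a 5.4-fold higher number from compound 1 to compound 3 (0.74 log units; beyond the scatter) and a 4.9-fold higher number from compound 2 to compound 3 (0.69 log units; beyond the scatter) show, and both steps are beyond the scatter. Those two neighbours do not separate from each other, since a 1.1-fold higher number from compound 1 to compound 2 (0.05 log units; within the scatter) stays within the scatter.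

The next compound is compound 4 `FC(F)(F)c1cccc(NC(=S)Nc2cccc(Br)c2)c1`, which carries bromo in place of hydrogen on an aromatic carbon. Among the compounds with values here, no measured step adds bromo, so the evidence is indirect. The nearest guide is the pair of modest steps from compound 1 and compound 2, which show that the number in this assay is lower when 4-ethylcyclohexyl or 4-butylcyclohexyl stands on an aromatic carbon instead of hydrogen. Lengthening that substituent, as in a 1.1-fold higher number from compound 1 to compound 2 (0.05 log units; within the scatter), moved nothing beyond the scatter. Bromo is a different and far smaller substituent, so only part of those steps is expected to carry over. The expected change is a 2.0-fold lower number from compound 3 to compound 4 (0.29 log units; within the scatter), towards a lower number and close to the edge of the scatter. For compound 4 the value is estimated at 25000 nM, with an expected range of 11000 nM to 55000 nM.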

Compound 4, half-maximal cytotoxic concentration: 10000 nM
For compound 4 the middle estimate is 2.5-fold (0.40 log units) above the measured one; measured number below the stated range.
By their numbers in this assay, from the lowest: compounds 1, 2 and 4 (each within the scatter of the next); then compound 3.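

In this assay, the move a 4.9-fold lower number from compound 3 to compound 4 (0.69 log units; beyond the scatter) shows that this one position on the phenyl ring, meta to a large group, is not indifferent: replacing a hydrogen atom with bromo is enough to carry the number beyond the scatter. The earlier steps shown here had tied a lower number only to the much larger 4-ethylcyclohexyl and 4-butylcyclohexyl groups, yet bromo, with 1 heavy atom and no ring, gives a step of the same printed size as a 4.9-fold higher number from compound 2 to compound 3 (0.69 log units; beyond the scatter), though the two steps involve different places on the ring. Among the compounds shown, then, the size of the entering group does not set the size of the step, and nothing measured here bears on why the number falls at this position.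

The compounds shown leave open whether this lower number belongs to bromo itself or would also follow from a chloro, a methoxy or an amine on the same carbon. They also leave open whether bromo on another carbon of that ring would give a step of similar size, or one within the scatter.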